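The compounds below may be only part of what the source reports. "The series", "measured", "known", "first", "only" and "open" are said of these compounds alone.

Measured so far in a physicochemical assay for lipophilicity; on this read-out lower numbers stand for lower lipophilicity and higher numbers for higher lipophilicity:
- compound 1 `C#CC(C)OC[n+]1ccn(C)c1/C=N/O`: -2.14
- compound 2 `CC#CC(C)OC[n+]1ccn(C)c1/C=N/O`: -1.74
- compound 3 `C#CCC(C)OC[n+]1ccn(C)c1/C=N/O`: -2.1

Compound 3 belongs to the lower pair of the three: the numbers show a number 0.04 log units higher from compound 1 to compound 3 (within the scatter) and a number 0.36 log units lower from compound 2 to compound 3 (beyond the scatter). The change to compound 4 `C#CC(C)C(C)OC[n+]1ccn(C)c1/C=N/O` is methyl in place of hydrogen on a saturated chain carbon bound to a saturated chain carbon and a triple-bonded carbon. Within the data shown here, two measured steps bear on it. Methyl in place of hydrogen on a triple-bonded carbon gave a number 0.40 log units higher from compound 1 to compound 2 (beyond the scatter), while propargyl in place of ethynyl gave a number 0.04 log units higher from compound 1 to compound 3 (within the scatter). Neither places a methyl at this spot, so a modest rise in this assay is expected, no larger than the first of these. The expected step is a number 0.25 log units higher from compound 3 to compound 4 (within the scatter). Compound 4 is estimated at -1.85, with an expected range of -2.1 to -1.6.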

Compound 4, distribution coefficient: -1.55
For compound 4 the middle estimate is 0.30 log units below the measured one; measured number outside the range, above it.
By their numbers in this assay, from the lowest: compounds 1 and 3 (each within the scatter of the next); then compounds 2 and 4 (each within the scatter of the next).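

In this assay methyl in place of hydrogen on a saturated chain carbon bound to a saturated chain carbon and a triple-bonded carbon gave a number 0.55 log units higher from compound 3 to compound 4 (beyond the scatter) and thus showed that this position responds to the change. The 1-methylprop-2-yn-1-yl group gave a number 0.59 log units higher from compound 1 to compound 4 (beyond the scatter) in place of ethynyl, yet in place of prop-1-yn-1-yl it gave a number 0.19 log units higher from compound 2 to compound 4 (within the scatter) and so leaves those two compounds level. No measured evidence accounts for these steps.

On these data alone, whether ethyl or hydroxymethyl at this carbon would behave as methyl does remains open. So does whether a methyl on the triple-bonded carbon of compound 4 would add to this step.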